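Replacing methoxy with cyano: what compound 4 may show

The source may hold more compounds than are shown below. What is called first, only, known or untested is meant among the compounds shown, and "the series" means these compounds.

Going by the values given here, in a functional assay on MGC-803 cells (Homo sapiens) for inhibition, read by MTT assay, with a stated time of 72 h (a higher number here means a weaker inhibitor, a lower number a stronger inhibitor), compound 1 (`COc1ccc(NC(=O)C2CCN(C/C=C/c3ccccc3)CC2)cc1`) gives 58200 nM, the highest of the three numbers measured so far and so the weakest inhibitor of the set. Compound 2 (`O=C(Nc1cccc(C(F)(F)F)c1)C1CCN(C/C=C/c2ccccc2)CC1`) gives 9590 nM. Compound 3 (`O=C(Nc1ccc(F)c(Br)c1)C1CCN(C/C=C/c2ccccc2)CC1`) gives 9270 nM.

The next compound to be tested is compound 4 (`N#Cc1ccc(NC(=O)C2CCN(C/C=C/c3ccccc3)CC2)cc1`), which keeps the core of compound 1 and changes one group: cyano in place of methoxy on an aromatic carbon. Put another way, the 4-methoxyphenyl of compound 1 becomes a 4-cyanophenyl in compound 4.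

Among the compounds with values here, no measured compound carries cyano, so the evidence is indirect. The closest guide is a 6.3-fold lower number from compound 1 to compound 3 (0.80 log units; beyond the scatter), a step beyond the scatter that also removes the 4-methoxyphenyl. Compound 2, which lacks that group as well, shows a similar drop at 9590 nM. Neither of the two compounds without the 4-methoxyphenyl goes against this trend, though they are only two. A step in the same direction is therefore expected in this assay, probably somewhat smaller, and the estimated step is a 3.6-fold lower number from compound 1 to compound 4 (0.56 log units; beyond the scatter). The expected value for compound 4 is 16000 nM, with an estimated range of 6000 nM to 42000 nM.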

Compound 4, half-maximal inhibitory concentration: 28200 nM
For compound 4 the middle estimate is 1.8-fold (0.25 log units) below the measured one; the measured number falls inside the stated range.
By their numbers in this assay, from the lowest: compounds 3 and 2 (each within the scatter of the next); then compound 4; then compound 1.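

In this assay, going by these compounds alone, there is a 2.1-fold lower number from compound 1 to compound 4 (0.31 log units; beyond the scatter) for cyano in place of methoxy, the first reading of a change of this single group on an aromatic carbon para to a large group. Methoxy and cyano match in heavy atoms and in hydrogen-bond acceptors as counted, so those counts alone do not separate the two compounds. With a 3.0-fold higher number from compound 3 to compound 4 (0.48 log units; beyond the scatter) on the amide-type nitrogen, the 4-cyanophenyl gives only part of the drop seen with the 3-bromo-4-fluorophenyl, so the groups that replace the 4-methoxyphenyl do not all lower the number equally.

The compounds shown leave open whether an amine, a carboxylic acid or a longer chain such as ethoxy at this place would move the number in the same direction as cyano. They also leave open how a lone bromine or a lone fluorine would read on this ring, as compound 3 carries both together. No measurement at hand speaks to why the number moves with any of these changes.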